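The compounds below may be only part of what the source reports. "The series", "measured", "known", "first", "only" and "open" are said of these compounds alone.

Compound 1, with the structure `COc1ccc(-c2cc(=O)c3c(OC)cc(OC)cc3[nH]2)cc1`, is the starting point of this account. In a functional assay on HepG2 cells (Homo sapiens) for antiproliferative activity, with a stated time of 72 h (on this read-out lower numbers stand for an effect already at smaller amounts and higher numbers for an effect only at larger amounts of compound), compound 1 gives only a limit, > 31100 nM, and not a number. The two other compounds measured in this assay stand the same way. Compound 2, `COc1ccc(-c2cc(=O)c3c(OC)cc(OC)cc3n2S(=O)(=O)c2ccc([N+](=O)[O-])cc2)cc1`, returns in this assay a limit of > 29300 nM. Compound 3, `COc1ccc(-c2cc(=O)c3c(OC)cc(OC)cc3n2S(=O)(=O)c2cccc([N+](=O)[O-])c2)cc1`, returns in this assay a limit of > 39600 nM. Compound 1 therefore stands nowhere within the numbers shown: every value on this read-out is a limit, and the step that the two limits leave unreadable from compound 2 to compound 3 is unreadable for that reason, as the lines (the limit of > 29300 nM in this assay, at which 1 of the 3 values shown sits), the limit of > 31100 nM in this assay, at which 1 of the 3 values shown sits, and the limit of > 39600 nM in this assay, at which 1 of the 3 values shown sits, show.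

Compound 4, `COc1ccc(-c2cc(=O)c3c(OC)cc(OC)cc3n2S(=O)(=O)c2ccc(Cl)cc2)cc1`, carries the change (4-chlorophenyl)sulfonyl in place of hydrogen on an aromatic nitrogen relative to compound 1. Among the measured compounds shown here, no measured step bears directly on this change, since the only step within the set concerns the nitrophenyl groups on a sulfonyl sulfur and its size is not readable. What the set does show is that adding a sulfonyl-linked aryl group to the aromatic nitrogen of compound 1 left compounds 2 and 3 at the limit of this assay. Compound 4 is thus expected to sit at or beyond that same limit, with a step that the limit leaves unreadable from compound 1 to compound 4 expected to be indistinguishable from none. Compound 4 is estimated at 40000 nM, within 15000 nM to 100000 nM.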

Compound 4, half-maximal effective concentration: > 34400 nM
Compound 4 ended at the assay's limit; the forecaster's own chance of this, stated with the estimate: 80%; the middle value is on the limit's open side.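

In this assay compound 4 gives only a limit, > 34400 nM. Its steps from compound 1, compound 2 and compound 3 therefore cannot be read. The compounds shown leave open whether any group on the aromatic nitrogen, or any change on the sulfonyl-linked aryl group, would bring this read-out to an actual number.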